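The source may report more compounds than this note shows. Statements on the series, on what has been measured and on what is new or still open speak of the compounds shown alone.

Among the measured compounds shown here, in an ADME assay on L6 cells (Rattus norvegicus) for cytotoxicity, read by resazurin assay, with a stated time of 72 h (a higher number here means a weaker inhibitor, a lower number a stronger inhibitor), compound 1 (`Cc1ccc(C(=O)NC(=O)c2ccccc2O)cc1`) gives 46 ug/mL and compound 2 (`CC(C)c1ccc(C(=O)NC(=O)c2ccccc2O)cc1`) gives 19 ug/mL, so compound 1 holds the higher of the two numbers known so far. The two compounds differ in one place only, the group on an aromatic carbon. Compound 3 (`O=C(NC(=O)c1ccccc1O)c1ccc(F)cc1`) keeps the core of compound 1 and changes that same group: fluoro in place of methyl on an aromatic carbon. In short, this is fluoro in place of methyl on an aromatic carbon. For the measured compounds named here, only one measured step bears on this change, and it is a modest one: a 2.4-fold lower number from compound 1 to compound 2 (0.38 log units; beyond the scatter), with isopropyl in place of methyl on an aromatic carbon. That step also removes the methyl, but it brings in a different group, so it offers a guide to size and only a weak hint on direction. Going by the values given here, no compound with fluoro has been measured yet. A step no larger than that one is therefore expected in this assay, perhaps toward a slightly higher number. The estimated step is a 1.1-fold higher number from compound 1 to compound 3 (0.05 log units; within the scatter). For compound 3 the expected value is 52 ug/mL, within an estimated range from 24 ug/mL to 105 ug/mL.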

Compound 3, half-maximal inhibitory concentration: 38 ug/mL
For compound 3 the middle estimate is 1.4-fold (0.14 log units) above the measured one, and the stated range covers the measured number.
By their numbers in this assay, from the lowest: compounds 2, 3 and 1 (each within the scatter of the next, the first and the last beyond it).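

In this assay, fluoro in place of methyl on this aromatic carbon, para to a large group, gives a step that cannot be told apart from the normal spread of repeated measurements (a 1.2-fold lower number from compound 1 to compound 3 (0.08 log units; within the scatter)), and the comparison with isopropyl also stays within the scatter (a 2.0-fold higher number from compound 2 to compound 3 (0.30 log units; within the scatter)). Compound 3 therefore cannot be separated from either of the other two compounds, even though the step between methyl and isopropyl lies beyond the scatter (a 2.4-fold lower number from compound 1 to compound 2 (0.38 log units; beyond the scatter)), so the fluoro result overlaps both ends of that one modest step. No measurement is available that could explain why these three groups give the numbers they do.

As far as these compounds go, it remains open whether other groups at this place, such as chloro, methoxy, an amine or a carboxylic acid, would stay close to these three numbers or give a step clearly beyond the scatter. Three groups on one shared core also leave open whether a longer chain would extend the step seen from methyl to isopropyl, and whether the same changes would behave alike on a different core.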